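A few compounds are considered here, and "the series" means these few. Any claim that something is new, unique, unknown or untested is made for them only; others in the source may bear on it.

Compound 2 `CC1=C(/C=C/C(=O)/C=C/c2ccc(Br)cc2)C(C)(C)CCC1` gives 10400 nM in a functional assay on IMR-32 cells (Homo sapiens) for cytotoxicity, read by sulforhodamine B assay, with a stated time of 48 h (a higher number here means a weaker inhibitor, a lower number a stronger inhibitor), the lowest of the three numbers shown, yet within the scatter of both compound 3 `COc1ccccc1/C=C/C(=O)/C=C/C1=C(C)CCCC1(C)C` at 19200 nM and compound 1 `CC1=C(/C=C/C(=O)/C=C/c2ccccc2)C(C)(C)CCC1` at 20400 nM. Compound 4 `CC1=C(/C=C/C(=O)/C=C/c2ccccc2F)C(C)(C)CCC1` is not yet measured; it carries 2-fluorophenyl in place of 4-bromophenyl on a double-bonded chain carbon bound to a double-bonded chain carbon. Among the compounds with values here, two measured steps bear on a substituent change on the aromatic ring: a 2.0-fold lower number from compound 1 to compound 2 (0.29 log units; within the scatter) and a 1.1-fold lower number from compound 1 to compound 3 (0.03 log units; within the scatter), neither beyond the scatter. Swapping one aromatic substituent for another is therefore expected to move this assay little, and the step of a 1.4-fold higher number from compound 2 to compound 4 (0.16 log units; within the scatter) is estimated to stay within the scatter. For compound 4 the expected value is 15000 nM, with a range from 6000 nM to 40000 nM.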

Compound 4, half-maximal inhibitory concentration: 15600 nM
Compound 4: the middle estimate sits 1.0-fold (0.02 log units) below what was measured, and the stated range covers the measured number.
By their numbers in this assay, from the lowest: compounds 2, 4, 3 and 1 (each within the scatter of the next).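

The step of a 1.5-fold higher number from compound 2 to compound 4 (0.18 log units; within the scatter) in this assay shows that changing both the halogen and its ring location in a single move still leaves the number within the scatter. Fluoro also stays within the scatter of hydrogen and methoxy, with a 1.3-fold lower number from compound 1 to compound 4 (0.12 log units; within the scatter) and a 1.2-fold lower number from compound 3 to compound 4 (0.09 log units; within the scatter) on the same core. No measurement shown accounts for this flat result.

Going by these compounds, whether the halogen or its location counts more on its own stays open, as a 4-fluorophenyl group would be needed to separate them. On these data alone, the effect of an amine or a carboxylic acid on the aromatic ring is also open.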